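Swapping the acid-bearing ring for a cyclic sulfone

The source may report more compounds than this note shows. Statements on the series, on what has been measured and on what is new or still open speak of the compounds shown alone.

Measured so far in an ADME assay on microsomes from liver (Mus musculus) for metabolic stability, with a stated time of 10 min; on this read-out higher numbers stand for a more stable compound and lower numbers for a less stable compound:
- compound 1, `C[C@]1(C(=O)O)CC[C@H](C(=O)N2CC[C@](c3ccc(C(F)(C(F)(F)F)C(F)(F)F)cc3)(S(=O)(=O)c3ccc(F)cc3)C2)CC1`: 93%
- compound 2, `C[C@]1(C(=O)N2CC[C@](c3ccc(C(F)(C(F)(F)F)C(F)(F)F)cc3)(S(=O)(=O)c3ccc(F)cc3)C2)CC[C@H](C(=O)O)CC1`: 95%
- compound 3, `O=C1NC(=O)C2(CCC(C(=O)N3CC[C@](c4ccc(C(F)(C(F)(F)F)C(F)(F)F)cc4)(S(=O)(=O)c4ccc(F)cc4)C3)CC2)N1`: 81%; 82% (2 entries)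

Compound 2 holds the highest of the two single numbers, with compound 1 nearest, and the step of a number 2 percentage points higher from compound 1 to compound 2 (within the scatter) lies within the scatter. Compound 3 has several entries, as the line the several entries of compound 3 in this assay, 81%; 82% (2 entries) shows, and these sit somewhat under the numbers of compound 1 and compound 2.

Compound 4, `O=C(C1CCS(=O)(=O)CC1)N1CC[C@](c2ccc(C(F)(C(F)(F)F)C(F)(F)F)cc2)(S(=O)(=O)c2ccc(F)cc2)C1`, is not yet measured. It differs from compound 2 in one place: 1,1-dioxothian-4-yl in place of 4-carboxy-1-methylcyclohexyl on a carbonyl carbon. Going by the values given here, no measured step covers this change; the one measured step, from compound 1 to compound 2, only moved the 4-carboxy-4-methylcyclohexyl group and stayed within the scatter, and compound 3, which also lacks the acid, gives numbers a little lower than compound 2. On that basis compound 4 is expected to land at 85%, between 65% and 97%, a modest expected step of a number 10 percentage points lower from compound 2 to compound 4 (within the scatter) that may well stay within the scatter.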

Compound 4, percent of the compound remaining: 96%
Beside the measured number, compound 4's estimate is 11 percentage points below it, within the range that was stated.
By their numbers in this assay, from the lowest: compounds 1, 2 and 4 (each within the scatter of the next).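

In this assay the swap to 1,1-dioxothian-4-yl on the carbonyl carbon gives a number 1 percentage points higher from compound 2 to compound 4 (within the scatter) and also a number 3 percentage points higher from compound 1 to compound 4 (within the scatter) when the 4-carboxy-4-methylcyclohexyl group is the one replaced. The earlier step only moved the methyl group and the carboxylic acid around the same carbon ring, whereas this change removes both that ring and the acid, and a high number is still found at this position without them. Nothing measured here explains why this is so.

As far as these compounds go, whether an amine in that ring, or an open longer alkyl chain on the carbonyl carbon, would give a similar number stays open. So does whether the sulfone is needed at all, which a ring with an ether oxygen in its place would test.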